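This account rests on a few compounds, and the source may have more. Where it says the series, first, only, none or still open, it means among the compounds named here.

Measured compounds:
- compound 1 `O=C(CI)NCCCCCC(=O)NCCCCCCNc1ncnc2c1ncn2[C@@H]1O[C@H](COP(=O)(O)OP(=O)(O)OP(=O)(O)O)[C@@H](O)[C@H]1O`, in an assay on isolated protein for inhibition of hexokinase-2 (Rattus norvegicus), with a stated time of 6 h, tested at 10 mM (a lower number here means less inhibition, a higher number more inhibition at the concentration tested (going by the name of the read-out)), compound 1 gives 0%
- compound 2 `O=C(CI)NCCCCCCCCNc1ncnc2c1ncn2[C@@H]1O[C@H](COP(=O)(O)OP(=O)(O)OP(=O)(O)O)[C@@H](O)[C@H]1O`, in this assay compound 2 gives 41%
- compound 3 `O=C(CI)NCCCCC(=O)NCCCCCCNc1ncnc2c1ncn2[C@@H]1O[C@H](COP(=O)(O)OP(=O)(O)OP(=O)(O)O)[C@@H](O)[C@H]1O`, in this assay compound 3 gives 0%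

Compound 3 stands level with compound 1 at the digits shown, the two together the lowest of the three numbers in this assay; compound 2 is the furthest from it, with a number higher by a number 41 percentage points lower from compound 2 to compound 3 (beyond the scatter) read in the other direction.

Compound 4 `O=C(CI)NCCCCCCC(=O)NCCCCCCNc1ncnc2c1ncn2[C@@H]1O[C@H](COP(=O)(O)OP(=O)(O)OP(=O)(O)O)[C@@H](O)[C@H]1O` is the next member. It differs from compound 3 by 2-(((iodomethyl)carbonyl)amino)ethyl in place of ((iodomethyl)carbonyl)amino on a saturated chain carbon, four bonds along the chain from a carbonyl carbon.

Within the data shown here, two measured steps bear on this. The first, no change at the digits printed from compound 1 to compound 3 (within the scatter), shortens the same segment by one chain carbon with no change beyond the scatter. The second, a number 41 percentage points lower from compound 2 to compound 3 (beyond the scatter), is a different kind of change, replacing the whole inner amide-containing group, and is large; it does not speak directly to a chain extension within that segment. The nearest comparison is therefore the step from compound 1 to compound 3, which suggests that lengthening this segment by two carbons should again give no step beyond the scatter in this assay.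

Compound 4 is expected to give 4% in this assay, with a range of 0% to 22%. The expected step is a number 4 percentage points higher from compound 3 to compound 4 (within the scatter), within the scatter.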

Compound 4, a percentage reported as inhibition, at one concentration (the size of the read-out at that concentration, not a potency): 0%
Compound 4: the middle estimate sits 4 percentage points above what was measured; measured number inside the range.
By their numbers in this assay, from the lowest: compounds 1, 3 and 4 (each within the scatter of the next); then compound 2.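

In this assay, 2-(((iodomethyl)carbonyl)amino)ethyl in place of ((iodomethyl)carbonyl)amino on a saturated chain carbon, four bonds along the chain from a carbonyl carbon, gives no change at the digits printed from compound 3 to compound 4 (within the scatter) and the one-carbon extension gives no change at the digits printed from compound 1 to compound 4 (within the scatter) in the same segment. Where the earlier compounds offered a single chain-length step, three lengths of this segment now read alike with the inner amide in place, with compound 4 at 0% in this assay and compound 2 still the only compound in the set with a nonzero reading, at 41% in the same assay. No supporting measurement accounts for this flat reading.

As far as these compounds go, a longer chain beyond that of compound 4, or an amine or ether oxygen in place of the inner amide, remains open, so it is unknown whether any inner-amide compound can leave the zero reading. All of these numbers come from one concentration, and identical zero readings for compound 1, compound 3 and compound 4 cannot separate the three chain lengths from one another.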